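Bromo to chloro on the aryloxy chain: two cores

The compounds below may be only part of what the source reports. "The series", "measured", "known", "first", "only" and "open" are said of these compounds alone.

Of the compounds shown here, three have been read in an assay on isolated protein for inhibition of Dihydrofolate reductase (Homo sapiens), read by spectrophotometry, using NADPH, with stated times of 5 s and 6 min, tested at 50 uM; a higher number here means a stronger effect of the compound at the concentration tested, a lower number a weaker effect. Compound 1 `NC1=NC2(CCSCC2)N(OCCCOc2ccccc2Br)C(N)=N1` gives 89.6% there. Compound 3 `NC1=NC2(CCSCC2)N(OCCCOc2ccccc2Cl)C(N)=N1` differs from compound 1 by chloro in place of bromo on an aromatic carbon, and in this assay compound 3 gives 89.6%. The step is no change at the digits printed from compound 1 to compound 3 (within the scatter).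

Compound 2 `NC1=NC2(CCOCC2)N(OCCCOc2cccc(Br)c2)C(N)=N1` carries a different core; the difference between the cores of compound 1 and compound 2 is not broken down here. In this assay compound 2 gives 85.8%, a number within the scatter of the other two readings, so no ordering among the three is claimed.

Compound 4 `NC1=NC2(CCOCC2)N(OCCCOc2cccc(Cl)c2)C(N)=N1` has not been measured. It differs from compound 2 by chloro in place of bromo on an aromatic carbon. The surroundings are not identical to the earlier pair: in compound 1 and compound 3 the halogen sits ortho to a large group, whereas in compound 2 and compound 4 it sits meta to a large group, so this is the same kind of change, not the same change.

The step from compound 2 to compound 4 is expected to be a number 0.8 percentage points lower from compound 2 to compound 4 (within the scatter), essentially flat, because no change at the digits printed from compound 1 to compound 3 (within the scatter) showed no movement for the same kind of swap on the other core. On that basis compound 4 is estimated to give 85% in this assay. The expected range for compound 4 runs from 75% to 93%.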

Compound 4, a percentage reported as inhibition, at one concentration (the size of the read-out at that concentration, not a potency): 85.8%
The estimate for compound 4 lay 0.8 percentage points below the measured number; the range from low to high includes it.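

In this assay, chloro in place of bromo on the ring of the second core gives no change at the digits printed from compound 2 to compound 4 (within the scatter). This shows that the swap reads the same on both cores, so within these two pairs the outcome on one core carried over to the other: the same change on two cores in this assay, no change at the digits printed (within the scatter) from compound 1 to compound 3 and no change at the digits printed (within the scatter) from compound 2 to compound 4, 0 percentage points apart, within the scatter of two such steps. For the compounds shown here, it does not establish a rule for the series, as only two pairs are available, the halogen sits in a different place on the ring in each pair, and each reading gives only the size of the effect at one concentration, so a stronger or weaker effect of bromo and chloro compounds at other concentrations could go unseen in these readings.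

Compounds 1 and 2 differ in both the core and the halogen's place on the ring, so the compounds shown leave the contribution of each of these two features unresolved. Also open, going by these compounds, is whether the flat result extends to fluoro, methoxy or trifluoromethyl on the same ring, or to a longer chain between the core and the phenoxy group.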